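Methyl for Chloro Where Three Values Sit at a Limit

The source may hold more compounds than are shown below. What is called first, only, known or untested is meant among the compounds shown, and "the series" means these compounds.

The measured compounds:
Compound 1 `Clc1ccc(C2ON=C(c3ccccc3Cl)O2)cc1` gives > 100000 nM in an ADME assay on HEK293 cells (Homo sapiens) for cytotoxicity, read by MTT assay, with a stated time of 44 h (a higher number here means a weaker inhibitor, a lower number a stronger inhibitor), a limit of the assay rather than a number.
Compound 2 `Cc1ccc(C2ON=C(c3ccccc3Cl)O2)cc1` gives > 100000 nM in this assay, again a limit.
Compound 3 `Clc1ccc(C2ON=C(c3cccc(Cl)c3)O2)cc1` gives > 100000 nM in this assay, also a limit.

From compound 1 to compound 2 the change is methyl in place of chloro on an aromatic carbon. The step that the two limits leave unreadable from compound 1 to compound 2 is not readable, because of the limit of > 100000 nM in this assay, at which 3 of the 3 values shown sit; both ends of it are limits. The cores of compound 1 and compound 3 hold the same atoms joined differently, and the difference between the two cores is not broken down here. Compound 4 `Cc1ccc(C2ON=C(c3cccc(Cl)c3)O2)cc1` is not yet measured. It differs from compound 3 by methyl in place of chloro on an aromatic carbon, the same change as from compound 1 to compound 2. Since all three values rest at the limit, the writer expects the step that the limit leaves unreadable from compound 3 to compound 4 to stay within that picture, and expects compound 4 to give about 200000 nM, most likely again reported only as a limit, with a plausible range from 100000 nM to 500000 nM.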

Compound 4, half-maximal inhibitory concentration: > 100000 nM
Compound 4 ended at the assay's limit (the forecaster's own chance of this, stated with the estimate: 85%); the middle value is on the limit's open side.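

In this assay compound 4 gives > 100000 nM as a limit of the assay, not a number. For the compounds shown here, no step from compound 3 to compound 4 can be read, because both ends are limits: the limit of > 100000 nM in this assay, at which 4 of the 4 values shown sit. The compounds shown leave open what any of them does to these cells at a readable value, and whether methyl in place of chloro changes it.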